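This account rests on a few compounds, and the source may have more. Where it says the series, first, only, none or still open, it means among the compounds named here.

In a functional assay on MDA-MB-231 cells (Homo sapiens) for cytotoxicity, read by MTT assay, with a stated time of 48 h (on this read-out lower numbers stand for stronger inhibition and higher numbers for weaker inhibition), three compounds have been tested so far. Compound 1 (`O=C(OCCCC(c1ccc(F)cc1)c1ccc(F)cc1)c1cc(Cl)c(OCc2ccccc2)c(Cl)c1`) gives > 20000 nM, which is a limit of the assay and not a number. Compound 2 (`Cc1ccc(NC(=O)NCCCCC(c2ccc(F)cc2)c2ccc(F)cc2)cc1`) gives > 20000 nM, again a limit. Among the compounds with values here, compound 3 (`O=C(NCCCCC(c1ccc(F)cc1)c1ccc(F)cc1)Nc1cccc(Cl)c1`) gives 5070 nM, the only actual number of the three.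

Compound 4 (`O=C(NCCCCC(c1ccc(F)cc1)c1ccc(F)cc1)Nc1ccc([N+](=O)[O-])c(Cl)c1`) is the next to be read. It differs from compound 3 as follows: nitro in place of hydrogen on an aromatic carbon. In words, this is nitro in place of hydrogen on an aromatic carbon, which turns 3-chlorophenyl into 3-chloro-4-nitrophenyl.

Within the data shown here, only one measured step bears on this change: an at least 3.9-fold lower number from compound 2 to compound 3 (0.59 log units; beyond the scatter), where 3-chlorophenyl replaces 4-methylphenyl on an amide-type nitrogen. That step shows that the substituents on this aromatic ring can move the read-out in this assay, but it says nothing direct about a nitro group. Going by these compounds, its true size also stays open because of the limit of > 20000 nM in this assay, at which 2 of the 3 values shown sit.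

A clear step in either direction is therefore not expected, only a slight lean towards a lower number, following the direction seen in an at least 3.9-fold lower number from compound 2 to compound 3 (0.59 log units; beyond the scatter). The expected change is a 1.4-fold lower number from compound 3 to compound 4 (0.16 log units; within the scatter), which would stay within the scatter. For compound 4 the estimated value is 3500 nM, with an expected range from 1000 nM to 14000 nM.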

Compound 4, half-maximal inhibitory concentration: 3470 nM
The estimate for compound 4 lay 1.0-fold (0.00 log units) above the measured number, and the stated range covers the measured number.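

In this assay, nitro on an aromatic carbon of the ring of compound 3, ortho to a chloro group and para to a large group, gives a 1.5-fold lower number from compound 3 to compound 4 (0.16 log units; within the scatter), so the read-out does not separate the two compounds and the added group brings no clear gain or loss at this position. The earlier compounds shown here could not show this, since they held no nitro group; the comparison with the 4-methylphenyl compound now gives an at least 5.7-fold lower number from compound 2 to compound 4 (0.76 log units; beyond the scatter), so the 3-chloro-4-nitrophenyl group, like 3-chlorophenyl, stands on the side of the lower number in that comparison. The value of compound 2 in that step is a limit and not a number, so the true size of the step stays open: the limit of > 20000 nM in this assay, at which 2 of the 4 values shown sit.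

Going by these compounds, whether an amine or a carboxylic acid at the same position of the ring would give a number different from that of compound 3 stays open, as does whether nitro would behave the same way on a ring without the chloro group. On these data alone, it is equally open how a longer chain in the shared core would read in this assay.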